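Two ether side chains on the shared core

This account rests on a few compounds, and the source may have more. Where it says the series, first, only, none or still open, it means among the compounds named here.

compound 1 `CCC(COC)Nc1nc(C)nc2c1nnn2-c1ccc(C(C)C)cc1Br` — 7.5 nM; 6.1 nM; 9.4 nM (3 entries)
compound 2 `CCC(CC)Oc1nc(C)nc2c1nnn2-c1ccc(C(C)C)cc1Br` — 1.9 nM

Of the compounds shown here, two built on the same core have been tested in an in vitro assay on 293-EBNA cells for binding affinity to corticotropin-releasing factor receptor 1 (Homo sapiens); a lower number here means a stronger inhibitor, a higher number a weaker inhibitor. Compound 1 carries an amine-linked side chain and has more than one entry in this assay, (the several entries of compound 1 in this assay, 7.5 nM; 6.1 nM; 9.4 nM (3 entries)). Compound 2 carries a pentan-3-yl group on a ring oxygen and gives 1.9 nM in this assay, the only number shown for it; one further entry for compound 2 has no single number.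

Compound 3 `COCC(COC)Oc1nc(C)nc2c1nnn2-c1ccc(C(C)C)cc1Br` keeps the oxygen link of compound 2 but changes the side chain: 2-methoxy-1-(methoxymethyl)ethyl in place of pentan-3-yl on an oxygen on an aromatic ring. Among the measured compounds shown here, no measured pair shows the effect of such a change. A modest weakening is expected, not clearly beyond the usual scatter. Compound 3 is therefore estimated at 4 nM in this assay, with a range from 1.5 nM to 12 nM. The expected step is a 2.1-fold higher number from compound 2 to compound 3 (0.32 log units; beyond the scatter).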

Compound 3, inhibition constant: 7.1 nM
Compound 3: middle estimate off by 1.8-fold (0.25 log units), on the low side; the measured number falls inside the stated range.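

In this assay, putting 2-methoxy-1-(methoxymethyl)ethyl in place of pentan-3-yl on the oxygen gives a 3.7-fold higher number from compound 2 to compound 3 (0.57 log units; beyond the scatter), the first single-place comparison available on this core. It shows that binding at this position responds to the make-up of the side chain, and that this swap, which brings in two hydrogen-bond acceptors, goes with a weaker inhibitor, not a stronger one. The step is larger than the spread among repeated readings of one compound: the several entries of compound 1 in this assay, 7.5 nM; 6.1 nM; 9.4 nM (3 entries)

The compounds shown leave open whether the weakening comes from one methoxy arm or from both, and how a cyclopentyl ring or a hydroxyl group in place of the methoxy groups would fare on this oxygen. They also leave open whether the same swap would act alike on the amine link of compound 1.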